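The source may hold more compounds than are shown below. What is called first, only, known or untested is meant among the compounds shown, and "the series" means these compounds.

In a functional assay on BXPC-3 cells (Homo sapiens) for inhibition, read by XTT assay, with a stated time of 72 h (a higher number here means a weaker inhibitor, a lower number a stronger inhibitor), the measured compounds are these
Compound 1 `C=CCCCCCCCCCOC[C@@H]1CCCN1C(=O)OC(C)(C)C` gives 50000 nM
Compound 2 `C=CCCCCCCOC[C@@H]1CCCN1[S+]([O-])c1ccc(C)cc1` gives 50000 nM

Compound 2 stands level with compound 1 on these numbers, so neither can be called the stronger inhibitor. The next compound to consider is compound 3 `C=CCCCCCCCCCOC[C@@H]1CCCN1[S+]([O-])c1ccc(C)cc1`, which differs from compound 2 in one place. The change is pent-4-en-1-yl in place of vinyl on a saturated chain carbon, six bonds along the chain from an oxygen on a saturated carbon and it lies on the chain: pent-4-en-1-yl takes the place of vinyl on a saturated chain carbon, six bonds along the chain from an oxygen on a saturated carbon. Going by the values given here, no measured pair of compounds shows this change on its own, so there is no direct precedent for it. Among the compounds with values here, the only guides are compound 2 at 50000 nM and compound 1 at 50000 nM, which sit level. In this assay no step beyond the scatter is therefore expected, though a small move would more likely be towards a stronger inhibitor than a weaker one. The expected step is a 1.7-fold lower number from compound 2 to compound 3 (0.22 log units; within the scatter) as an estimate. Compound 3 is estimated at 30000 nM with an expected range from 10000 nM to 60000 nM in this measurement.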

Compound 3, half-maximal inhibitory concentration: 50000 nM
Compound 3: middle estimate off by 1.7-fold (0.22 log units), on the low side; the measured number falls inside the stated range.
By their numbers in this assay, from the lowest: compounds 1, 2 and 3 (each within the scatter of the next).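

In this assay the longer pent-4-en-1-yl in place of vinyl, on a saturated chain carbon six bonds along the chain from an oxygen on a saturated carbon, gives no change at the digits printed from compound 2 to compound 3 (within the scatter), so this chain position has now been tested directly and the swap leaves the number within the scatter. Compound 3 also allows a second single-place comparison, on the amine nitrogen in a ring: a group of 9 heavy atoms with a six-membered aromatic ring in place of a group of 7 heavy atoms with no ring gives no change at the digits printed from compound 1 to compound 3 (within the scatter), so neither change separates these compounds in this cell assay. Nothing available explains why the three compounds give the same printed number.

With all three numbers level, these compounds do not show what, if anything, would produce a stronger inhibitor in this assay here. On these data alone, it remains open whether an amine or a carboxylic acid in place of pent-4-en-1-yl, or a different group on the ring nitrogen, would give a different number.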